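A few compounds are considered here, and "the series" means these few. Any claim that something is new, unique, unknown or untested is made for them only; others in the source may bear on it.

Measured so far:
compound 1 `CCCCCCNC(=O)n1cc(F)c(=O)n(C)c1=O`
compound 2 `CCCCCCNC(=O)n1cc(F)c(=O)n(CC)c1=O`
compound 3 `CCCCCCNC(=O)n1cc(F)c(=O)n(C(=O)OCC(C)C)c1=O`

In an assay on HEK293 cells for inhibition of acid ceramidase (Rattus norvegicus), read by LC-MS, with a stated time of 30 min (a lower number here means a stronger inhibitor, a higher number a weaker inhibitor), compound 1 gives 13 nM. Compound 2 gives 18 nM. Compound 3 gives 16 nM, the second highest of the three numbers; its steps to the others, a 1.2-fold higher number from compound 1 to compound 3 (0.09 log units; within the scatter) and a 1.1-fold lower number from compound 2 to compound 3 (0.05 log units; within the scatter), both lie within the scatter, so nothing separates it from them.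

Compound 4 `CCCCCCNC(=O)n1cc(F)c(=O)n(C(=O)c2ccccc2)c1=O` differs from compound 3 by phenyl in place of isobutoxy on a carbonyl carbon, that is isobutoxycarbonyl to benzoyl. For the measured compounds named here, the only steps on record at this aromatic nitrogen are a 1.4-fold higher number from compound 1 to compound 2 (0.14 log units; within the scatter), a 1.2-fold higher number from compound 1 to compound 3 (0.09 log units; within the scatter) and a 1.1-fold lower number from compound 2 to compound 3 (0.05 log units; within the scatter), all within the scatter; no step varies the carbonyl's other neighbour itself. The series has so far tolerated every change at this position, so the expected step is no change at the digits printed from compound 3 to compound 4 (within the scatter), none beyond the scatter. For compound 4 the estimate is 16 nM, with a range of 7 nM to 40 nM.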

Compound 4, half-maximal inhibitory concentration: 20 nM
Beside the measured number, compound 4's estimate is 1.3-fold (0.10 log units) below it; the range from low to high includes it.
By their numbers in this assay, from the lowest: compounds 1, 3, 2 and 4 (each within the scatter of the next).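

Benzoyl on the aromatic nitrogen keeps the number in this assay level with the earlier compounds, and all three new steps lie within the scatter (a 1.3-fold higher number from compound 3 to compound 4 (0.10 log units; within the scatter); a 1.1-fold higher number from compound 2 to compound 4 (0.05 log units; within the scatter); a 1.5-fold higher number from compound 1 to compound 4 (0.19 log units; within the scatter)). The range tolerated at this position now includes a six-membered aromatic ring of carbon only on the carbonyl carbon, alongside the isobutoxy of compound 3. No measurement at hand explains this flat response.

Going by these compounds, whether an amine or a carboxylic acid on the group at this nitrogen would hold the number remains open. So does the effect of a bare hydrogen on this nitrogen.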